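A few compounds are considered here, and "the series" means these few. Any claim that something is new, unique, unknown or untested is made for them only; others in the source may bear on it.

Working notes on a small set of cyclohexyl ureas. Compound 1 `Cc1ccc(NC(=O)N[C@H]2CC[C@H](Oc3ccc(F)cc3)CC2)cc1` carries a methyl group on its aryl urea part. In a functional assay on CRL2813 cells (Homo sapiens) for cytotoxicity, read by sulforhodamine B assay, with a stated time of 5 days (on this read-out lower numbers stand for stronger inhibition and higher numbers for weaker inhibition), compound 1 gives only a limit of the assay, > 20000 nM. Compound 2 `O=C(Nc1ccccc1OC(F)(F)F)N[C@H]1CC[C@H](Oc2ccc(F)cc2)CC1` carries a trifluoromethoxy group instead. In this assay compound 2 likewise gives only a limit, > 20000 nM. Within the data shown here, both values shown therefore sit at the limit of > 20000 nM in this assay, at which 2 of the 2 values shown sit, so no measured step between compounds can be computed, and nothing in the numbers separates compound 2 from compound 1.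

Compound 3 `O=C(Nc1ccccc1F)N[C@H]1CC[C@H](Oc2ccc(F)cc2)CC1` differs from compound 2 by fluoro in place of trifluoromethoxy on an aromatic carbon, ortho to a large group. Since no measured step exists in this assay, the direction of this change cannot be read from the data shown. The expected step in this assay is a number no higher from compound 2 to compound 3 (the limit leaves the size open), that is, none beyond the usual scatter, with compound 3 most likely remaining at the limit. For compound 3 the estimate in this assay is 20000 nM, within 5000 nM to 80000 nM.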

Compound 3, half-maximal inhibitory concentration: 17500 nM
Compound 3: the middle estimate sits 1.1-fold (0.06 log units) above what was measured; measured number inside the range.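

Compound 3 is the only one of the three that gives a number rather than a limit of the assay in this assay: the limit of > 20000 nM in this assay, at which 2 of the 3 values shown sit.

With fluoro in place of trifluoromethoxy on an aromatic carbon, ortho to a large group, the read-out shows an at least 1.1-fold lower number from compound 2 to compound 3 (0.05 log units; that floor lies within the scatter), and 2-fluorophenyl in place of 4-methylphenyl on an amide-type nitrogen shows an at least 1.1-fold lower number from compound 1 to compound 3 (0.05 log units; that floor lies within the scatter). Each of these steps starts from a limit, so it gives only a floor and no size, and that floor does not separate compound 3 from the other two beyond the usual scatter.

The compounds shown leave open whether a different group on this aromatic carbon, such as an amine, a carboxylic acid or a methoxy group, would bring the number in this assay clearly down from that of compound 3. They also leave open how far the true values of compound 1 and compound 2 lie from compound 3, and whether any change to the rest of the shared core would matter more than a change on this aromatic carbon.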